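From chloro to methoxy on compound 1

This account rests on a few compounds, and the source may have more. Where it says the series, first, only, none or still open, it means among the compounds named here.

Measured so far in a functional assay on HepG2 cells (Homo sapiens) for antiproliferative activity, read by MTT assay, with a stated time of 72 h (a higher number here means a weaker inhibitor, a lower number a stronger inhibitor), are two compounds:
Compound 1 `COc1cc(CCc2ccccc2Cl)cc(OC)c1O` gives 2190 nM
Compound 2 `COc1cc(CCc2ccc(Cl)cc2Cl)cc(OC)c1O` gives 6740 nM

Compound 1 has the lower of these two numbers and so is the stronger inhibitor. Compound 3 `COc1ccccc1CCc1cc(OC)c(O)c(OC)c1` carries methoxy in place of chloro on an aromatic carbon, ortho to a large group (methoxy in place of chloro on an aromatic carbon). Within the data shown here, the only measured step is a 3.1-fold higher number from compound 1 to compound 2 (0.49 log units; beyond the scatter) for chloro in place of hydrogen on an aromatic carbon. That is a different change and only a rough guide to size. A modest step toward a higher number is therefore expected in this assay with low confidence. This estimate means a 1.6-fold higher number from compound 1 to compound 3 (0.20 log units; within the scatter) as the expected step. Compound 3 is expected to give 3500 nM (estimated range 1100 nM to 11000 nM).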

Compound 3, half-maximal inhibitory concentration: 2480 nM
Compound 3: middle estimate off by 1.4-fold (0.15 log units), on the high side; low and high end bracket the measured number.
By their numbers in this assay, from the lowest: compounds 1 and 3 (each within the scatter of the next); then compound 2.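

Compound 1 and compound 3 cannot be told apart here: the step is a 1.1-fold higher number from compound 1 to compound 3 (0.05 log units; within the scatter). So on this aromatic carbon, ortho to a large group, a methoxy with its two heavy atoms and one hydrogen-bond acceptor reads the same as a single chlorine, whereas the earlier step concerned adding a chloro rather than replacing one. Nothing available explains why these two groups read alike. Still open, from the compounds shown here alone, is whether an amine or a carboxylic acid at this place would also leave the number unmoved. Also open, going by these compounds, is whether a longer chain, such as ethoxy, would do so.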